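A few compounds are considered here, and "the series" means these few. Any claim that something is new, unique, unknown or untested is made for them only; others in the source may bear on it.

Measured so far, in a toxicity assay on THP-1 cells (Homo sapiens) for inhibition; a lower number here means that less compound is tolerated, a higher number that more compound is tolerated:

Compound 1 `COc1ccc(-c2cnc(NC(=O)c3ccc(Br)cc3)n2C)cc1` gives > 100000 nM, which is a limit of the assay and not a number.
Compound 2 `Cn1cc(-c2ccccc2)nc1NC(=O)c1ccc(F)cc1` gives > 50000 nM, again a limit.
Compound 3 `Cn1c(-c2ccccc2)cnc1NC(=O)c1ccc(Br)cc1` gives > 100000 nM, again a limit.

Compound 1 therefore stands only at a limit in this assay, and the two other values are limits as well. The one step that connects two of these compounds, from compound 1 to compound 3, is a step that the two limits leave unreadable from compound 1 to compound 3: because both ends sit at limits, the step cannot be read. Among the compounds with values here, what the three values do show is the limit of > 100000 nM in this assay, at which 2 of the 3 values shown sit, and (the limit of > 50000 nM in this assay, at which 1 of the 3 values shown sits); no compound here has a numerical half-maximal cytotoxic concentration.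

Compound 4 `COc1ccc(-c2cnc(NC(=O)c3cccc(Cl)c3)n2C)cc1` differs from compound 1 by 3-chlorophenyl in place of 4-bromophenyl on a carbonyl carbon. The 4-bromophenyl leaves and a 3-chlorophenyl enters, at the carbonyl carbon next to the amide-type nitrogen. Within the data shown here, no measured step bears on this change, and the only measured step, from compound 1 to compound 3, is itself unreadable. The expectation for this assay is therefore no step beyond the scatter, and compound 4 is expected to sit at a limit too, with a step that the limit leaves unreadable from compound 1 to compound 4 as the step meant. The estimate for compound 4 in this assay is 150000 nM, in a range from 50000 nM to 500000 nM.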

Compound 4, half-maximal cytotoxic concentration: > 28000 nM
Compound 4 was reported as a limit; the forecaster's own chance of this, stated with the estimate: 85%; the middle value lies beyond the limit too.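

In this assay compound 4 gives > 28000 nM, which is a limit of the assay and not a number. Compound 1 also stands at a limit, so the step from compound 1 to compound 4 cannot be read. The compounds shown leave open what half-maximal cytotoxic concentration any of them has, and whether 3-chlorophenyl in place of 4-bromophenyl changes it.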